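A few compounds are considered here, and "the series" means these few. Any claim that something is new, unique, unknown or untested is made for them only; others in the source may bear on it.

Compound 1 `Fc1ccc(-c2ccc(-c3ccc(-c4nc5ccccc5[nH]4)cc3)cc2)cc1`: in a functional assay on KB cells (Homo sapiens) for inhibition, read by sulforhodamine B assay (on this read-out higher numbers stand for weaker inhibition of growth and lower numbers for stronger inhibition of growth), compound 1 gives 41300 nM.
Compound 2 `Oc1cccc2[nH]c(-c3ccc(-c4ccc(-c5ccc(F)cc5)cc4)cc3)nc12`: in this assay compound 2 gives 6920 nM.

Compound 2 holds the lowest number of the two, and the nearest to it is compound 1, since the change a 6.0-fold lower number from compound 1 to compound 2 (0.78 log units; beyond the scatter) set them apart by more than the scatter. Compound 3 `COc1ccc(-c2ccc(-c3ccc(-c4nc5c(O)cccc5[nH]4)cc3)cc2)cc1OC` has not yet been measured. It differs from compound 2 in one place: 3,4-dimethoxyphenyl in place of 4-fluorophenyl on an aromatic carbon. Within the data shown here, the only measured step, a 6.0-fold lower number from compound 1 to compound 2 (0.78 log units; beyond the scatter), concerns a hydroxy group and says nothing about exchanging a 4-fluorophenyl for a 3,4-dimethoxyphenyl, so no measured step bears on this change. With no guidance from the data, the step of a 1.0-fold higher number from compound 2 to compound 3 (0.00 log units; within the scatter) is expected to stay within the scatter, and compound 3 is estimated at 7000 nM, with a wide range from 1500 nM to 30000 nM.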

Compound 3, concentration for 50% growth inhibition: 2710 nM
Compound 3: middle estimate off by 2.6-fold (0.41 log units), on the high side; the measured number falls inside the stated range.
By their numbers in this assay, from the lowest: compound 3; then compound 2; then compound 1.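

In this assay, putting 3,4-dimethoxyphenyl in place of 4-fluorophenyl gives a 2.6-fold lower number from compound 2 to compound 3 (0.41 log units; beyond the scatter). This shows that the group on this aromatic carbon, para to a large group, can shift growth inhibition by more than the scatter, whereas the earlier step spoke only about the hydroxy group. Nothing measured here accounts for this gain in inhibition.

As far as these compounds go, the step removes the fluorine and adds both methoxy groups at once, and which of these changes matters remains open. Also open, from the compounds shown here alone, are how a group such as an amine or a carboxylic acid would behave on this aromatic carbon, and whether the hydroxy group would have the same effect on a compound carrying 3,4-dimethoxyphenyl.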